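Ester side-chain variation on the shared core, metabolic stability

A few compounds are considered here, and "the series" means these few. Any claim that something is new, unique, unknown or untested is made for them only; others in the source may bear on it.

Compound 1 `CCCCc1nc(C(C)C)c(CC(=O)OC(CC)CC)c(=O)n1Cc1ccc(-c2ccccc2-c2noc(=O)[nH]2)cc1` and compound 2 `CC#CCOC(=O)Cc1c(C(C)C)nc(CCCC)n(Cc2ccc(-c3ccccc3-c3noc(=O)[nH]3)cc2)c1=O` share one core and differ only in the alcohol part of the side-chain ester, but-2-yn-1-yl in compound 2 in place of pentan-3-yl in compound 1. In an ADME assay on microsomes from liver (Mus musculus) for metabolic stability, with a stated time of 30 min (on this read-out lower numbers stand for a less stable compound and higher numbers for a more stable compound), compound 1 gives 14.6%. In this assay compound 2 gives 16.4%. Going by the values given here, compound 2 thus carries the higher of the two numbers recorded so far, but the only measured step, a number 1.8 percentage points higher from compound 1 to compound 2 (within the scatter), lies within the scatter, so the two values cannot be ordered against each other.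

Compound 3 `CCCCc1nc(C(C)C)c(C(C)C(=O)OCC)c(=O)n1Cc1ccc(-c2ccccc2-c2noc(=O)[nH]2)cc1` has not been measured. It differs from compound 2 by 1-(ethoxycarbonyl)ethyl in place of (((but-2-yn-1-yl)oxy)carbonyl)methyl on an aromatic carbon. Part of this change, the exchange of the alcohol portion of the ester, is of the same kind as the one measured step, a number 1.8 percentage points higher from compound 1 to compound 2 (within the scatter), which stayed within the scatter. For the branching of the entering group no measured comparison exists. On this basis no step beyond the scatter is expected in this assay from compound 2 to compound 3.

Compound 3 is therefore estimated at 17% in this assay, with a range from 7% to 32%, an expected step of a number 0.6 percentage points higher from compound 2 to compound 3 (within the scatter).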

Compound 3, percent of the compound remaining: 28%
Compound 3: middle estimate off by 11 percentage points, on the low side, and the stated range covers the measured number.
By their numbers in this assay, from the lowest: compounds 1 and 2 (each within the scatter of the next); then compound 3.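

In this assay, going by these compounds alone, the 1-(ethoxycarbonyl)ethyl group on the aromatic carbon ortho to the isopropyl group gives the first steps beyond the scatter, with a number 11.6 percentage points higher from compound 2 to compound 3 (beyond the scatter) and also a number 13.4 percentage points higher from compound 1 to compound 3 (beyond the scatter) as the two readings of this change. The position therefore responds on this read-out to a change of the whole side chain, whereas the exchange of the alcohol part alone, a number 1.8 percentage points higher from compound 1 to compound 2 (within the scatter), did not separate the two compounds. The entering group differs from both leaving groups in the alcohol part and in the branching on the carbon attached to the ring, so these steps cannot be assigned to either feature, and no measured data on the origin of the steps are available.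

Open, as far as these compounds go, is how the unbranched (ethoxycarbonyl)methyl group would read, which would separate the branching from the change of alcohol part. Also open, from the compounds shown here alone, is how a carboxylic acid or an amide in place of the ester at this position, or a longer chain in the alcohol part of the branched ester, would stand in this assay against these compounds.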